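A few compounds are considered here, and "the series" means these few. Any claim that something is new, unique, unknown or untested is made for them only; others in the source may bear on it.

Compound 1 `CC(C)(C)Cc1c(-c2ccc(Cl)cc2)sc(N)c1C(=O)c1ccc(Cl)cc1` and compound 2 `Cc1ccc(-c2sc(N)c(C(=O)c3ccc(Cl)cc3)c2CC(C)(C)C)cc1` share one core and differ in a single group. In an assay on CHO cells for displacement of a labelled ligand from adenosine receptor A3 (Homo sapiens), read by scintillation counting, tested at 10 uM (a lower number here means less inhibition, a higher number more inhibition at the concentration tested (going by the name of the read-out)), compound 1 gives 1%, and in this assay compound 2 gives 1%, so compound 2 stands level with compound 1 at the digits shown. Among the measured compounds shown here, the one step measured so far, no change at the digits printed from compound 1 to compound 2 (within the scatter), shows that swapping methyl for chloro on an aromatic carbon left the read-out unchanged within the scatter.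

Compound 3 `Cc1cccc(-c2sc(N)c(C(=O)c3ccc(Cl)cc3)c2CC(C)(C)C)c1` is the next compound to be tested. The difference from compound 2 is 3-methylphenyl in place of 4-methylphenyl on an aromatic carbon; the two have the same atoms, joined differently. For the measured compounds named here, no measured step moves a methyl from one position of this ring to another, so the only guide is that the one step known, from compound 1 to compound 2, did nothing beyond the scatter. The expected step in this assay is therefore no change at the digits printed from compound 2 to compound 3 (within the scatter), none beyond the scatter. Compound 3 is estimated to give 1%, within the range -8% to 10%.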

Compound 3, a percentage reported as inhibition, at one concentration (the size of the read-out at that concentration, not a potency): 1%
The estimate for compound 3 equals the measured number at the digits printed, and the stated range covers the measured number.
By their numbers in this assay, from the lowest: compounds 1, 2 and 3 (each within the scatter of the next).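

Moving the methyl within this ring, which the earlier compounds did not do, gives in this assay no change at the digits printed from compound 2 to compound 3 (within the scatter), so on this evidence its place on the phenyl ring makes no visible difference. Compared with the 4-chlorophenyl group, the 3-methylphenyl group gives no change at the digits printed from compound 1 to compound 3 (within the scatter), so all three aryl groups on this ring carbon next to the ring sulfur read alike, with compound 3 at 1%. No measurement shown here offers an explanation for this flat result.

What the compounds leave open is whether a phenyl ring carrying a carboxylic acid or an amine at this place would give a different read-out. Also open, as far as these compounds go, is whether replacing the neopentyl group with a longer chain, or changing the amino group, would alter the inhibition seen with the shared core.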